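The compounds below may be only part of what the source reports. "The series", "measured", "known", "first", "only" and "open" are said of these compounds alone.

Measured compounds:
Compound 1, `O=C(/C=C/c1cccnc1)NCCCCCCc1cccc(S(=O)(=O)Nc2ccccc2)c1` — 10.5 nM
Compound 2, `Cc1ccc(NS(=O)(=O)c2cccc(CCCCCCNC(=O)/C=C/c3cccnc3)c2)cc1` — 9.78 nM
Compound 3, `O=C(/C=C/c1cccnc1)NCCCCCCc1cccc(S(=O)(=O)Nc2ccc(Cl)cc2)c1` — 10.8 nM

All three numbers come from an assay on isolated protein for inhibition of Nicotinamide phosphoribosyltransferase (Homo sapiens), read by WST assay, with stated times of 60 min, 5 min and 30 min, in the presence of a further agent that is not named here; a higher number here means a weaker inhibitor, a lower number a stronger inhibitor. Among them compound 1 stands second highest; its nearest neighbour is compound 3, a 1.0-fold higher number from compound 1 to compound 3 (0.01 log units; within the scatter), and its furthest is compound 2, a 1.1-fold lower number from compound 1 to compound 2 (0.03 log units; within the scatter). The three measurements therefore sit within the scatter of one another, and no order among them can be read from the data.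

Compound 4, `O=C(/C=C/c1cccnc1)NCCCCCCc1cccc(S(=O)(=O)Nc2ccc(C(F)(F)F)cc2)c1`, has not yet been measured in this assay. It differs from compound 1 in one place: trifluoromethyl in place of hydrogen on an aromatic carbon.

Within the data shown here, the measured steps that bear on this change are the two from compound 1, a 1.1-fold lower number from compound 1 to compound 2 (0.03 log units; within the scatter) and a 1.0-fold higher number from compound 1 to compound 3 (0.01 log units; within the scatter), and the one between the substituted pair, a 1.1-fold higher number from compound 2 to compound 3 (0.04 log units; within the scatter). Each places a small group at the same position of the shared core, and each leaves the number within the scatter. On that basis a trifluoromethyl at this position is expected to give a step no larger than the scatter in this assay, in neither direction, so that compound 4 is estimated at 10.5 nM, with a range from 5 nM to 22 nM, corresponding to no change at the digits printed from compound 1 to compound 4 (within the scatter).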

Compound 4, half-maximal inhibitory concentration: 24.5 nM
Beside the measured number, compound 4's estimate is 2.3-fold (0.37 log units) below it; the whole stated range lies below it.
By their numbers in this assay, from the lowest: compounds 2, 1 and 3 (each within the scatter of the next); then compound 4.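

In this assay, the position para to a large group on this aromatic ring proves not to be indifferent to what it carries: trifluoromethyl in place of hydrogen gives a 2.3-fold higher number from compound 1 to compound 4 (0.37 log units; beyond the scatter) whereas methyl and chloro had each left the number within the scatter. The departure also holds against the two substituted compounds, with a 2.3-fold higher number from compound 3 to compound 4 (0.36 log units; beyond the scatter) and a 2.5-fold higher number from compound 2 to compound 4 (0.40 log units; beyond the scatter) so that compound 4 is the weakest of the four whichever compound serves as the reference, although all three steps are modest. No measurement shown here accounts for this step.

With a single group standing apart from the others, the compounds shown cannot settle whether trifluoromethyl is an isolated case or part of a wider trend at this carbon, which a methoxy, a nitrile, an amine or a carboxylic acid in the same place would help to show. From the compounds shown here alone, it also remains open whether trifluoromethyl would give a similar step on another carbon of this ring or alongside a shorter or longer chain.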